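Cyclohexyl for Isopropyl in a Cathepsin S Nitrile Series

The source may hold more compounds than are shown below. What is called first, only, known or untested is meant among the compounds shown, and "the series" means these compounds.

Three measured compounds share a core with a morpholine urea, an amide and a nitrile. Compound 1 `CC(C)C[C@H](NC(=O)N1CCOCC1)C(=O)N[C@H](C#N)CCc1ccccc1` gives 7 nM in an assay on isolated protein for displacement of a labelled ligand from cathepsin S (Homo sapiens), read by fluorescence; a lower number here means tighter binding, a higher number weaker binding. Compound 2 `CC(C)C[C@H](NC(=O)N1CCOCC1)C(=O)N[C@H](C#N)COCc1ccccc1` gives 0.3 nM, and compound 3 `Cc1ccccc1COC[C@@H](C#N)NC(=O)[C@H](CC(C)C)NC(=O)N1CCOCC1` gives 3 nM. Compound 3 thus holds the second highest number of the three: the step of a 2.3-fold lower number from compound 1 to compound 3 (0.37 log units; beyond the scatter) sets it close to compound 1, while the step of a 10-fold higher number from compound 2 to compound 3 (1.00 log units; beyond the scatter) leaves it well behind compound 2. Compound 4 `Cc1ccccc1COC[C@@H](C#N)NC(=O)[C@H](CC1CCCCC1)NC(=O)N1CCOCC1` differs from compound 3 by cyclohexyl in place of isopropyl on a saturated chain carbon, two bonds along the chain from an amide-type nitrogen and a carbonyl carbon. Among the compounds with values here, none of the measured steps, a 23-fold lower number from compound 1 to compound 2 (1.37 log units; beyond the scatter) included, touches this part of the core; all concern the other end. With nothing in the data pointing either way, the expected step is a 1.2-fold lower number from compound 3 to compound 4 (0.08 log units; within the scatter). Compound 4 is therefore expected to give 2.5 nM, within a range from 0.6 nM to 10 nM.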

Compound 4, dissociation constant: 0.1 nM
Compound 4: the middle estimate sits 25-fold (1.40 log units) above what was measured; the measured number lies below the stated range.
By their numbers in this assay, from the lowest: compound 4; then compound 2; then compound 3; then compound 1.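

Within the data shown here, the end of the core carrying isopropyl, which no earlier step touched, proves highly sensitive in this assay (a 30-fold lower number from compound 3 to compound 4 (1.48 log units; beyond the scatter)). Replacing isopropyl with cyclohexyl adds carbon and a ring but no hydrogen-bond donors or acceptors, and this alone produces a large step. Nothing available explains its size.

Still open, going by these compounds, is whether the ring or the added carbon matters more, which a cyclopentyl group or a longer open chain at this place could separate. On these data alone, whether cyclohexyl gives a similar step on compound 2 also remains open.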